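Changing the Amide Partner on a Shared Core

This account rests on a few compounds, and the source may have more. Where it says the series, first, only, none or still open, it means among the compounds named here.

Compound 1, `CCN(CC)S(=O)(=O)c1ccc(S(=O)(=O)N2CCC[C@@H](C(=O)N3CCC(O)CC3)C2)cc1`, gives 870 nM in a functional assay on MIA PaCa-2 cells (Homo sapiens) for inhibition, read by MTT assay, with a stated time of 7 days; a higher number here means a weaker inhibitor, a lower number a stronger inhibitor.
Compound 2, `CCN(CC)S(=O)(=O)c1ccc(S(=O)(=O)N2CCC[C@@H](C(=O)NC3COC3)C2)cc1`, gives 2340 nM in this assay.
Compound 3, `CCN(CC)S(=O)(=O)c1ccc(S(=O)(=O)N2CCC[C@@H](C(=O)N[C@@H]3CCOC3)C2)cc1`, gives 750 nM in this assay.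

Compound 3 has the lowest number of the three, but its gap to compound 1 is small: a 1.2-fold lower number from compound 1 to compound 3 (0.06 log units; within the scatter), which means the two cannot be told apart. Only compound 2 stands clearly apart, as a 3.1-fold lower number from compound 2 to compound 3 (0.49 log units; beyond the scatter) shows. Compound 4, `CCN(CC)S(=O)(=O)c1ccc(S(=O)(=O)N2CCC[C@@H](C(=O)N3CCS(=O)(=O)CC3)C2)cc1`, is the next member. It differs from compound 3 in one place: 1,1-dioxothiomorpholin-4-yl in place of (oxolan-3-yl)amino on a carbonyl carbon.

Two measured steps speak to this change. Going from the six-membered ring amide of compound 1 to the five-membered ring amine of compound 3 changed nothing beyond the scatter (a 1.2-fold lower number from compound 1 to compound 3 (0.06 log units; within the scatter)), while the smaller four-membered ring in compound 2 gave a modest rise (a 2.7-fold higher number from compound 1 to compound 2 (0.43 log units; beyond the scatter)). Compound 4 returns to a six-membered ring on the amide nitrogen, closer in size to compound 1 than to compound 2. The expectation for compound 4 is therefore a step that stays within the scatter, a 1.3-fold higher number from compound 3 to compound 4 (0.10 log units; within the scatter). Compound 4 is estimated at 950 nM, with a range from 400 nM to 2500 nM.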

Compound 4, half-maximal inhibitory concentration: 900 nM
Beside the measured number, compound 4's estimate is 1.1-fold (0.02 log units) above it, within the range that was stated.
By their numbers in this assay, from the lowest: compounds 3, 1 and 4 (each within the scatter of the next); then compound 2.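

The carbonyl carbon of this series accepts a bulkier partner carrying a sulfone-type ring without any shift in this assay: 1,1-dioxothiomorpholin-4-yl, with 8 heavy atoms, matches the 6 heavy atoms of (oxolan-3-yl)amino (a 1.2-fold higher number from compound 3 to compound 4 (0.08 log units; within the scatter)) and also matches the 4-hydroxypiperidin-1-yl partner (a 1.0-fold higher number from compound 1 to compound 4 (0.01 log units; within the scatter)). The new partner has 0 hydrogen-bond donors and no defined stereocentre, so neither the amide hydrogen nor the stereocentre of compound 3 is needed to hold the number at this level. Compound 2, with its (oxetan-3-yl)amino partner, now stands apart from all three others, and the new comparison confirms it (a 2.6-fold lower number from compound 2 to compound 4 (0.41 log units; beyond the scatter)), which makes compound 2 the weakest of the four. Nothing given here explains why these different partners give such similar numbers.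

Still open, as far as these compounds go, is whether a partner with no ring at all, such as diethylamino, would stay level with compounds 1, 3 and 4. The same question holds for a ring with a second nitrogen, such as piperazin-1-yl, or for a partner bearing a carboxylic acid.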